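The compounds below may be only part of what the source reports. "The series", "measured", "known", "first", "only" and "open" are said of these compounds alone.

In a functional assay on MCF7 cells (Homo sapiens) for cytotoxicity, read by MTT assay, with a stated time of 72 h (a higher number here means a weaker inhibitor, a lower number a stronger inhibitor), compound 1 `O=C(N/N=C/c1cccc(Br)c1)Nc1cc2c(Nc3ccc(F)c(Cl)c3)ncnc2cc1O[C@H]1CCOC1` gives 12400 nM, compound 2 `O=C(N/N=C/c1cccc(Cl)c1Cl)Nc1cc2c(Nc3ccc(F)c(Cl)c3)ncnc2cc1O[C@H]1CCOC1` is recorded as "not active" (no number reported), and compound 3 `COc1ccc(/C=N/NC(=O)Nc2cc3c(Nc4ccc(F)c(Cl)c4)ncnc3cc2O[C@H]2CCOC2)cc1` gives 27300 nM, the higher of the two numbers. Compound 4 `O=C(N/N=C/c1cc(Br)c(O)c(Br)c1)Nc1cc2c(Nc3ccc(F)c(Cl)c3)ncnc2cc1O[C@H]1CCOC1` has not been measured yet. It differs from compound 3 at one place: 3,5-dibromo-4-hydroxyphenyl in place of 4-methoxyphenyl on a carbon with a double bond to nitrogen. Going by the values given here, only one measured step bears on this, a 2.2-fold higher number from compound 1 to compound 3 (0.34 log units; beyond the scatter), which is modest and swaps 3-bromophenyl for 4-methoxyphenyl at that same place. The incoming group also carries bromine, so reversing that step suggests a lower number, although compound 2, with no number, warns against relying on this trend. A modest step is therefore expected, a 1.8-fold lower number from compound 3 to compound 4 (0.26 log units; within the scatter). For compound 4 the estimated value is 15000 nM, with an expected range from 5000 nM to 45000 nM.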

Compound 4, half-maximal inhibitory concentration: 5910 nM
Estimate against measurement, compound 4: 2.5-fold (0.40 log units) above; low and high end bracket the measured number.
By their numbers in this assay, from the lowest: compound 4; then compound 1; then compound 3.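

In this assay the group on a carbon with a double bond to nitrogen can lower the number: 3,5-dibromo-4-hydroxyphenyl gives a 4.6-fold lower number from compound 3 to compound 4 (0.66 log units; beyond the scatter) and also a 2.1-fold lower number from compound 1 to compound 4 (0.32 log units; beyond the scatter) so compound 4 has the lowest of the three numbers. Two halogens on this ring therefore do not always mean loss of activity, as the two chlorines of the "not active" compound 2 alone might have suggested. No measurement shown explains this change. Still open, on these data alone, is whether the bromine or the hydroxyl goes with the lower number, and how an amine or a carboxylic acid on that ring would read.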